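Benzyl halogen swap on the diamino core

This account rests on a few compounds, and the source may have more. Where it says the series, first, only, none or still open, it means among the compounds named here.

Measured so far in a functional assay on NCI-H23 cells (Homo sapiens) for inhibition, read by sulforhodamine B assay, with a stated time of 48 h; on this read-out lower numbers stand for stronger inhibition of growth and higher numbers for weaker inhibition of growth:
compound 1 `Nc1cc(N)c2nc(-c3ccccc3)c(NCc3ccc(Cl)c(Cl)c3)nc2c1` — 27500 nM
compound 2 `Nc1cc(N)c2nc(-c3ccccc3)c(Sc3ccc(Cl)c(Cl)c3)nc2c1` — 34700 nM
compound 3 `CCOC(=O)[C@H](CCC(=O)O)NC(=O)c1ccc(CNc2nc3cc(N)cc(N)c3nc2-c2ccccc2)cc1` — < 100000 nM

Compound 1 gives 27500 nM in this assay. Compound 2 gives 34700 nM in this assay, and the two numbers lie within the usual scatter of each other, so no order between compound 1 and compound 2 can be read from them. For compound 3 this assay reports only a limit, < 100000 nM, and not a number; this is the limit of < 100000 nM in this assay, at which 1 of the 3 values shown sits. For the measured compounds named here, compound 1 thus stands at one of the two actual numbers, with no step to any other compound large enough to count.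

Compound 4 `Nc1cc(N)c2nc(-c3ccccc3)c(NCc3ccc(F)cc3)nc2c1` has not yet been measured in this assay. It differs from compound 1 in one place: 4-fluorophenyl in place of 3,4-dichlorophenyl on a saturated chain carbon bound to a nitrogen on an aromatic ring. Going by the values given here, no measured pair covers this change, so the expected step rests on compound 1 alone. The step is expected to be small, at most about the scatter, and if anything toward weaker inhibition of growth, so that the estimated step of a 1.5-fold higher number from compound 1 to compound 4 (0.16 log units; within the scatter) is modest. Compound 4 is estimated at 40000 nM in this assay, within a range from 15000 nM to 100000 nM. The measurement will show whether this holds.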

Compound 4, concentration for total growth inhibition: 4570 nM
Compound 4: the middle estimate sits 8.8-fold (0.94 log units) above what was measured, and the stated range ends above it.
By their numbers in this assay, from the lowest: compound 4; then compounds 1 and 2 (each within the scatter of the next).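

In this assay, the group on the saturated chain carbon bound to a nitrogen on an aromatic ring proves able to move the read-out: 4-fluorophenyl in place of 3,4-dichlorophenyl gives a 6.0-fold lower number from compound 1 to compound 4 (0.78 log units; beyond the scatter) and thus a step beyond the scatter, which compound 1 and compound 2 alone did not show. The swap of (3,4-dichlorophenyl)sulfanyl for (4-fluorobenzyl)amino on an aromatic carbon gives a 7.6-fold lower number from compound 2 to compound 4 (0.88 log units; beyond the scatter) and changes the link and the ring substitution together, so it cannot assign the step to either one. No measurement shown accounts for the size of these steps.

With one change, the two chlorines leave and the fluorine enters, so the compounds shown do not separate loss of chlorine from gain of fluorine. An unsubstituted benzyl, a 4-chlorobenzyl or a 3,4-difluorobenzyl group at this place would divide those two contributions.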